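Aryl-oxazole piperazine amides: fluorophenyl positional swap

A few compounds are considered here, and "the series" means these few. Any claim that something is new, unique, unknown or untested is made for them only; others in the source may bear on it.

Measured so far:
compound 1, `COc1cc(OC)cc(N2CCN(C(=O)c3oc(C)nc3-c3ccc(F)cc3)CC2)c1`, 38.5 nM
compound 2, `CCc1nc(-c2cccc(F)c2)c(C(=O)N2CCN(c3cccc(OC)c3)CC2)o1`, 201 nM
compound 3, `COc1cc(OC)cc(N2CCN(C(=O)c3oc(C)nc3-c3cccc(F)c3)CC2)c1`, 28.2 nM

In a functional assay on HL-60 cells (Homo sapiens) for inhibition, read by MTT assay, with a stated time of 72 h (on this read-out lower numbers stand for stronger inhibition and higher numbers for weaker inhibition), compound 3 gives 28.2 nM and compound 1 gives 38.5 nM. The change between them is 4-fluorophenyl in place of 3-fluorophenyl on an aromatic carbon, and it made a 1.4-fold higher number from compound 3 to compound 1 (0.14 log units; within the scatter). Compound 2 stands apart: in this assay compound 2 gives 201 nM, the highest of the three numbers and beyond the scatter from both compound 1 and compound 3. The difference between the core of compound 2 and the core of compound 3 is not broken down here.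

Not yet measured is compound 4, `CCc1nc(-c2ccc(F)cc2)c(C(=O)N2CCN(c3cccc(OC)c3)CC2)o1`. It differs from compound 2 by 4-fluorophenyl in place of 3-fluorophenyl on an aromatic carbon. This is the same kind of change as from compound 3 to compound 1, but not the same: in compound 2 the ring atom two ring bonds away bears an ethyl group, whereas in compound 3 it bears a methyl group.

The step is expected to be a 1.2-fold higher number from compound 2 to compound 4 (0.08 log units; within the scatter), small and within the scatter, because a 1.4-fold higher number from compound 3 to compound 1 (0.14 log units; within the scatter). Compound 4 is therefore estimated at 240 nM, with the range 100 nM to 560 nM.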

Compound 4, half-maximal inhibitory concentration: 411 nM
Estimate against measurement, compound 4: 1.7-fold (0.23 log units) below; measured number inside the range.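

In this assay, the same replacement of 3-fluorophenyl by 4-fluorophenyl on the core of compound 2 gives a 2.0-fold higher number from compound 2 to compound 4 (0.31 log units; beyond the scatter), and the two steps seen so far cannot be told apart: the same change on two cores in this assay, a 1.4-fold higher number (0.14 log units; within the scatter) from compound 3 to compound 1 and a 2.0-fold higher number (0.31 log units; beyond the scatter) from compound 2 to compound 4, 1.5-fold (0.18 log units) apart, within the scatter of two such steps

Among these compounds, only the step on the core of compound 2 lies beyond the scatter, but that contrast is no evidence of a dependence on the core, so for these two cores a single modest step, or none beyond the scatter, describes the change adequately. Two cores are a narrow basis, however: this does not show that the change would carry to a third core, and it gives no reason for the size of either step.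

Still open, on these data alone, is whether the step stays this small with a longer chain, such as butyl, in place of the ethyl or methyl group on the ring. As far as these compounds go, it is also open what happens to the number when an amine or a carboxylic acid takes the place of the fluorine.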